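Replacing 4-Bromophenyl with Propyl

The source may report more compounds than this note shows. Statements on the series, on what has been measured and on what is new or still open speak of the compounds shown alone.

Of the compounds shown here, two built on a shared core have been measured in a functional assay on MCF7 cells (Homo sapiens) for inhibition, read by MTT assay, with a stated time of 48 h (a lower number here means a stronger inhibitor, a higher number a weaker inhibitor), so far. Compound 1 `COc1ccc(C(c2c[nH]c3ccc(Br)cc23)c2c[nH]c3ccc(Br)cc23)c(OC)c1` gives 77500 nM and compound 2 `Brc1ccc(C(c2c[nH]c3ccc(Br)cc23)c2c[nH]c3ccc(Br)cc23)cc1` gives 3200 nM as the lower of the two numbers, which makes it the stronger inhibitor of the pair. The next compound keeps that core but changes one group. Compound 3 `CCCC(c1c[nH]c2ccc(Br)cc12)c1c[nH]c2ccc(Br)cc12` carries propyl in place of 4-bromophenyl on a saturated chain carbon bound to two aromatic carbons, a swap counted as propyl in place of 4-bromophenyl on a saturated chain carbon bound to two aromatic carbons in full. Among the measured compounds shown here, only one measured step bears on this swap. It sits at the same place, and a 24-fold lower number from compound 1 to compound 2 (1.38 log units; beyond the scatter) is a large step, well beyond the scatter. For the measured compounds named here, that step exchanged one substituted phenyl group for another, though, and no measured compound has a chain here, so it hints at how far the number can move but not which way. With so little to go on, a moderate move towards a weaker inhibitor seems likeliest. The step expected in this assay is a 4.1-fold higher number from compound 2 to compound 3 (0.61 log units; beyond the scatter) as a rough estimate. Compound 3 is estimated at 13000 nM (expected range 3000 nM to 50000 nM).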

Compound 3, half-maximal inhibitory concentration: 3600 nM
Compound 3: the middle estimate sits 3.6-fold (0.56 log units) above what was measured, within the range that was stated.
By their numbers in this assay, from the lowest: compounds 2 and 3 (each within the scatter of the next); then compound 1.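

In this assay the swap gives a 1.1-fold higher number from compound 2 to compound 3 (0.05 log units; within the scatter) even though propyl, with 3 heavy atoms and no ring, replaces 4-bromophenyl, with 7 heavy atoms and a six-membered aromatic ring, so on a saturated chain carbon bound to two aromatic carbons this pair shows that a ring is not required to reach the number of compound 2. Among the compounds shown here, the other new comparison is a 22-fold lower number from compound 1 to compound 3 (1.33 log units; beyond the scatter) and it shows that a chain as well as a 4-bromophenyl group stands far from compound 1, which leaves 2,4-dimethoxyphenyl as the one group of the three with a clearly higher number. Nothing measured here gives a reason for these numbers.

As far as these compounds go, how far a chain can change at this position remains open, from a single methyl group to a longer chain such as hexyl, or a propyl chain ending in an amine or a carboxylic acid. From the compounds shown here alone, it is also open whether a phenyl ring with one methoxy group, such as 4-methoxyphenyl, would stand with compound 1 or with compound 2.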